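Para-substituent swap on the anilide of a chalcone-like series

The source may report more compounds than this note shows. Statements on the series, on what has been measured and on what is new or still open speak of the compounds shown alone.

Three compounds share one core. In a functional assay on 143B cells (Homo sapiens) for antiproliferative activity, read by MTT assay, with a stated time of 48 h (a higher number here means a weaker inhibitor, a lower number a stronger inhibitor), compound 1 `O=C(/C=C/c1cccc(NC(=O)c2ccccc2Cl)c1)c1nc2ccccc2[nH]1` gives 3690 nM, compound 2 `O=C(Nc1cccc(/C=C/C(=O)c2nc3ccccc3[nH]2)c1)c1ccc(Cl)cc1` gives 7440 nM, and compound 3 `Cc1ccc(C(=O)Nc2cccc(/C=C/C(=O)c3nc4ccccc4[nH]3)c2)cc1` gives 6560 nM. Compound 2 has the highest of the three numbers, yet a 2.0-fold higher number from compound 1 to compound 2 (0.30 log units; within the scatter) and a 1.1-fold lower number from compound 2 to compound 3 (0.05 log units; within the scatter) both lie within the scatter, so the three stand together. Compound 4 `COc1ccc(C(=O)Nc2cccc(/C=C/C(=O)c3nc4ccccc4[nH]3)c2)cc1` is not yet measured; it differs from compound 2 by methoxy in place of chloro on an aromatic carbon. The step of a 1.1-fold lower number from compound 2 to compound 3 (0.05 log units; within the scatter) is the closest guide, another exchange on that same aromatic carbon, and it stayed within the scatter. Compound 4 is therefore expected to sit near compound 2, with a 1.1-fold lower number from compound 2 to compound 4 (0.06 log units; within the scatter) expected not to exceed the scatter. The estimate for compound 4 in this assay is 6500 nM, within 2500 nM to 17000 nM.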

Compound 4, half-maximal inhibitory concentration: 6330 nM
Estimate against measurement, compound 4: 1.0-fold (0.01 log units) above; the measured number falls inside the stated range.
By their numbers in this assay, from the lowest: compounds 1, 4, 3 and 2 (each within the scatter of the next).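

In this assay, methoxy on this aromatic carbon, para to a large group, stays level with chloro, with a 1.2-fold lower number from compound 2 to compound 4 (0.07 log units; within the scatter) and, against methyl, with a 1.0-fold lower number from compound 3 to compound 4 (0.02 log units; within the scatter). Swapping the chlorine-bearing ring of compound 1 for 4-methoxyphenyl also stays level, with a 1.7-fold higher number from compound 1 to compound 4 (0.23 log units; within the scatter), so the hydrogen-bond acceptor that methoxy brings separates no compound here. Nothing available accounts for this flatness. As far as these compounds go, whether an amine or a carboxylic acid on this carbon would stay within the same span remains open, as does how methoxy would behave where compound 1 carries its chlorine.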